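Chloro in Place of Fluoro on Compound 1

The source may hold more compounds than are shown below. What is called first, only, known or untested is meant among the compounds shown, and "the series" means these compounds.

Measured compounds:
compound 1, `OC(CCn1nc2c(Br)c(Br)c(Br)c(Br)c2n1)c1ccc(F)cc1`, 0%
compound 2, `OC(CCn1nc2c(Br)c(Br)c(Br)c(Br)c2n1)c1ccccc1`, 21%
compound 3, `C[C@H](O)CCn1nc2c(Br)c(Br)c(Br)c(Br)c2n1`, 36%

In a functional assay on CCRF-CEM cells (Homo sapiens) for antiproliferative activity, read by MTT assay, with a stated time of 24 h, tested at 100 uM (on this read-out lower numbers stand for a stronger effect and higher numbers for a weaker effect at the one concentration tested), compound 1 gives 0%, the lowest of the three numbers, which on this read-out means the strongest effect seen. Its nearest neighbour is compound 2, and that step, a number 21 percentage points higher from compound 1 to compound 2 (beyond the scatter), lies beyond the scatter. Compound 3 stands furthest away with 36%.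

Compound 4, `OC(CCn1nc2c(Br)c(Br)c(Br)c(Br)c2n1)c1ccc(Cl)cc1`, has not yet been measured. It differs from compound 1 in one place: chloro in place of fluoro on an aromatic carbon. For the measured compounds named here, the only measured step that bears on this position is the one from compound 1 to compound 2, where removing the fluoro altogether moved the number upward by a modest amount. Here the fluoro is not removed but replaced by another halogen, chloro, so a change smaller than that step, or none beyond the scatter, is expected.

Since compound 1 already sits at the bottom of the scale, compound 4 is expected to stay close to it, with a number 6 percentage points higher from compound 1 to compound 4 (within the scatter) as the expected step. For compound 4 the estimate in this assay is 6%, with a range from 0% to 25%.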

Compound 4, a percentage reported as activity, at one concentration (the size of the read-out at that concentration, not a potency): 0%
The estimate for compound 4 lay 6 percentage points above the measured number; low and high end bracket the measured number.
By their numbers in this assay, from the lowest: compounds 1 and 4 (each within the scatter of the next); then compound 2; then compound 3.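

In this assay the exchange of 4-fluorophenyl for 4-chlorophenyl gives no change at the digits printed from compound 1 to compound 4 (within the scatter) and so, on this read-out, the two halogens cannot be told apart at this position. The step of a number 21 percentage points lower from compound 2 to compound 4 (beyond the scatter) runs opposite to a number 21 percentage points higher from compound 1 to compound 2 (beyond the scatter) and shows that among these three compounds, both halogens on this aromatic carbon go with a lower number than hydrogen, so the earlier effect of fluoro is not unique to that one halogen. Nothing measured here accounts for this shared result.

As far as these compounds go, compound 1 and compound 4 both sit at the bottom of the scale at the one concentration tested, so whether a difference between fluoro and chloro would appear at lower concentrations remains open. Also open, from the compounds shown here alone, is how a larger halogen such as bromo, or a methoxy group, an amine or a carboxylic acid, would read on the same aromatic carbon, and therefore how far this position tolerates anything other than fluoro or chloro.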